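The compounds below may be only part of what the source reports. "The series", "measured", "known", "first", "only" and "open" are said of these compounds alone.

The measured compounds so far:

compound 1, `COc1cc[nH]c1/C=C1\C(=O)Nc2ccc(F)c(C#C[C@@H](N)CO)c21`, which in a functional assay on MDA-MB-435 cells (Homo sapiens) for inhibition (a lower number here means a stronger inhibitor, a higher number a weaker inhibitor), gives 300 nM
compound 2, `CN[C@H](C#Cc1c(F)ccc2c1/C(=C/c1[nH]ccc1OC)C(=O)N2)CO`, which in this assay gives 349 nM
compound 3, `COc1cc[nH]c1/C=C1\C(=O)Nc2ccc(F)c(C#C[C@@H](N)[C@@H](C)O)c21`, which in this assay gives 300 nM

All three share one core and differ only in a short side chain on the triple-bonded carbon. Compound 1 and compound 2 differ by methyl in place of hydrogen on an amine nitrogen. That change produced a 1.2-fold higher number from compound 1 to compound 2 (0.07 log units; within the scatter). Compound 1 and compound 3 differ by methyl in place of hydrogen on a saturated chain carbon bound to an oxygen on a saturated carbon and a saturated chain carbon, and here no change at the digits printed from compound 1 to compound 3 (within the scatter). Between compound 2 and compound 3 the result was a 1.2-fold lower number from compound 2 to compound 3 (0.07 log units; within the scatter). All three numbers therefore sit in one cluster, with nothing to separate them.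

Compound 4, `CN[C@H](C#Cc1c(F)ccc2c1/C(=C/c1[nH]ccc1OC)C(=O)N2)[C@@H](C)O`, has not yet been measured in this assay. It differs from compound 3 by methyl in place of hydrogen on an amine nitrogen. The place of this change is the same word for word as in the change from compound 1 to compound 2, so it is the same change, only made on the core that already carries the extra methyl described by methyl in place of hydrogen on a saturated chain carbon bound to an oxygen on a saturated carbon and a saturated chain carbon. The expectation for compound 4 rests on two facts: the earlier methyl on the amine nitrogen gave a 1.2-fold higher number from compound 1 to compound 2 (0.07 log units; within the scatter), and compound 3 stands at 300 nM. For compound 4 this means an expected 1.2-fold higher number from compound 3 to compound 4 (0.07 log units; within the scatter). Compound 4 is thus estimated at 350 nM, most likely between 180 nM and 700 nM.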

Compound 4, half-maximal inhibitory concentration: 358 nM
Beside the measured number, compound 4's estimate is 1.0-fold (0.01 log units) below it; low and high end bracket the measured number.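

In this assay methyl in place of hydrogen on the amine nitrogen gives a 1.2-fold higher number from compound 3 to compound 4 (0.08 log units; within the scatter) and reads the same on both cores: the same change on two cores in this assay, a 1.2-fold higher number (0.07 log units; within the scatter) from compound 1 to compound 2 and a 1.2-fold higher number (0.08 log units; within the scatter) from compound 3 to compound 4, 1.0-fold (0.01 log units) apart, within the scatter of two such steps. Methyl in place of hydrogen on the saturated chain carbon bound to an oxygen gives a 1.0-fold higher number from compound 2 to compound 4 (0.01 log units; within the scatter) and also reads the same on both cores: the same change on two cores in this assay, no change at the digits printed (within the scatter) from compound 1 to compound 3 and a 1.0-fold higher number (0.01 log units; within the scatter) from compound 2 to compound 4, 1.0-fold (0.01 log units) apart, within the scatter of two such steps. With both methyl groups in place the result is a 1.2-fold higher number from compound 1 to compound 4 (0.08 log units; within the scatter) and all four compounds stay in one cluster, so neither change shifts the number beyond the scatter on either core, but steps this small do not show that a real effect carries from one core to another or that the two changes add up.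

An ethyl group or a second methyl on the amine nitrogen, or a longer chain on the saturated carbon bound to the oxygen, might or might not leave the number in this cluster. From the compounds shown here alone, it also stays open what an amide in place of the amine or a methyl ether in place of the hydroxyl would do to this flat picture.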